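A Carbamate Aryl Swap on a Shared Core

The source may hold more compounds than are shown below. What is called first, only, known or untested is meant among the compounds shown, and "the series" means these compounds.

In a functional assay on PANC-1 cells (Homo sapiens) for inhibition, read by MTT assay, with a stated time of 24 h, tested at 10 uM (on this read-out higher numbers stand for more inhibition at the one concentration tested (going by the name of the read-out) and lower numbers for less inhibition), compound 3 `COc1ccc(NC(=O)Oc2cc(=O)n(CCCO)c3c2CC(CC=C(C)C)C(C)(C)C3)cc1` gives 0%. It sits level with compound 2 `CC(C)=CCC1Cc2c(OCCCOc3ccc(Cl)cc3)cc(=O)n(CCCO)c2CC1(C)C`, which in this assay gives 0%, and these two are the lowest of the three numbers; compound 1 `CC(C)=CCC1Cc2c(OCCCNC(=O)c3ccc([N+](=O)[O-])cc3)cc(=O)n(CCCO)c2CC1(C)C` gives 9.1% in this assay, and the steps of a number 9.1 percentage points lower from compound 1 to compound 2 (within the scatter) and no change at the digits printed from compound 2 to compound 3 (within the scatter) both lie within the scatter.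

Compound 4 `CC(C)=CCC1Cc2c(OC(=O)Nc3ccc(F)c(Cl)c3)cc(=O)n(CCCO)c2CC1(C)C` differs from compound 3 in one place: 3-chloro-4-fluorophenyl in place of 4-methoxyphenyl on an amide-type nitrogen. For the measured compounds named here, no measured step touches this nitrogen-bound aryl group, and every measured step so far stayed within the scatter, so compound 4 is expected to show a step of a number 3 percentage points higher from compound 3 to compound 4 (within the scatter) that does not exceed the scatter. Compound 4 is therefore estimated at 3%, within a range from 0% to 15%.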

Compound 4, a percentage reported as inhibition, at one concentration (the size of the read-out at that concentration, not a potency): 0%
Beside the measured number, compound 4's estimate is 3 percentage points above it, and the stated range covers the measured number.
By their numbers in this assay, from the lowest: compounds 2, 3, 4 and 1 (each within the scatter of the next).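

In this assay, 3-chloro-4-fluorophenyl in place of 4-methoxyphenyl on the amide-type nitrogen gives no change at the digits printed from compound 3 to compound 4 (within the scatter), so this first measured change of the nitrogen-bound aryl group leaves the read-out unmoved. Exchanging 3-(4-chlorophenoxy)propyl on the oxygen for (3-chloro-4-fluorophenyl)carbamoyl likewise gives no change at the digits printed from compound 2 to compound 4 (within the scatter), which extends the same result to this second carbamate. No evidence bearing on this result is available.

On these data alone, whether a 4-aminophenyl or 4-carboxyphenyl group on this nitrogen would read differently in this assay remains open.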